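The source may hold more compounds than are shown below. What is called first, only, known or untested is meant among the compounds shown, and "the series" means these compounds.

Values in an ADME assay on Caco-2 cells (Homo sapiens) for inhibition, read by sulforhodamine B assay, with a stated time of 72 h; on this read-out lower numbers stand for stronger inhibition and higher numbers for weaker inhibition:
- compound 1 `CC(C)CNC(=C\C(=O)/C=C/c1ccc(O)cc1)/C=C/c1ccc(O)cc1`: > 25000 nM
- compound 2 `CCC(C)NC(=C\C(=O)/C=C/c1ccc(O)cc1)/C=C/c1ccc(O)cc1`: > 25000 nM
- compound 3 `O=C(/C=C(/C=C/c1ccc(O)cc1)NC1CCCCC1)/C=C/c1ccc(O)cc1`: not yet measured

Compound 2 stands at > 25000 nM, which is a limit of the assay and not a number. The two measured compounds share one reading: the limit of > 25000 nM in this assay, at which 2 of the 2 values shown sit. Compound 3 has cyclohexyl in place of sec-butyl on an amine nitrogen, a change counted as cyclohexyl in place of sec-butyl on an amine nitrogen. Going by the values given here, only one measured step bears on this change: a step that the two limits leave unreadable from compound 1 to compound 2, where sec-butyl replaces isobutyl on the same nitrogen. It gives no size to carry forward, so the expectation in this assay is for no step beyond the scatter, in either direction. The expected change is a step that the limit leaves unreadable from compound 2 to compound 3, and that estimate is only nominal. Compound 3 is estimated at 30000 nM, with an expected range of 12000 nM to 60000 nM, and it may well report only a limit too.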

Compound 3, half-maximal inhibitory concentration: > 25000 nM
Compound 3 gave a limit, no number (the forecaster's own chance of this, stated with the estimate: 65%); the middle value does not contradict the limit.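

In this assay compound 3 gives > 25000 nM, which is a limit of the assay and not a number. No step among compound 1, compound 2 and compound 3 can be read: the limit of > 25000 nM in this assay, at which 3 of the 3 values shown sit.

The compounds shown leave open whether any group on the amine nitrogen changes the inhibition at all.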